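The source may report more compounds than this note shows. Statements on the series, on what has been measured and on what is new or still open speak of the compounds shown alone.

In a functional assay on A549 cells (Homo sapiens) for antiproliferative activity, read by MTT assay, with a stated time of 72 h (a lower number here means a stronger inhibitor, a higher number a weaker inhibitor), compound 1 `COc1cc(F)c(NC(=O)c2ccnc(O)c2)cc1Nc1nccc(-c2cn(C)c3ccccc23)n1` gives 11700 nM. Within the data shown here, compound 2 `COc1ccc(C(=O)Nc2cc(Nc3nccc(-c4cn(C)c5ccccc45)n3)c(OC)cc2F)nc1` gives 8200 nM in this assay, which is the lowest of the two numbers available so far, with compound 1 as its nearest neighbour; the step of a 1.4-fold lower number from compound 1 to compound 2 (0.15 log units; within the scatter) lies within the scatter, so the two values cannot be separated. Compound 3 `COc1cc(F)c(NC(=O)c2cnccn2)cc1Nc1nccc(-c2cn(C)c3ccccc23)n1` has not yet been measured. It differs from compound 2 in one place: pyrazin-2-yl in place of 5-methoxypyridin-2-yl on a carbonyl carbon. Among the measured compounds shown here, the only measured step that bears on this position is a 1.4-fold lower number from compound 1 to compound 2 (0.15 log units; within the scatter), which also exchanged the aromatic ring on the carbonyl carbon and produced no change beyond the scatter. For the measured compounds named here, nothing among the measured compounds shows an exchange at this position moving this assay by more than the scatter, and the pyrazin-2-yl ring has no measured precedent. The expected step is therefore a 1.1-fold higher number from compound 2 to compound 3 (0.04 log units; within the scatter), which is not beyond the scatter and could fall in either direction. Compound 3 is estimated at 9000 nM in this assay, with a range from 3000 nM to 27000 nM.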

Compound 3, half-maximal inhibitory concentration: 2490 nM
Compound 3: the middle estimate sits 3.6-fold (0.56 log units) above what was measured; measured number outside the range, below it.
By their numbers in this assay, from the lowest: compound 3; then compounds 2 and 1 (each within the scatter of the next).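

In this assay, the ring on the carbonyl carbon of the amide proves able to move the number beyond the scatter: the earlier exchange (a 1.4-fold lower number from compound 1 to compound 2 (0.15 log units; within the scatter)) could not be separated from no change, whereas the new one (a 3.3-fold lower number from compound 2 to compound 3 (0.52 log units; beyond the scatter)) can, though its size is modest. The result holds against both measured pyridine-based rings, since pyrazin-2-yl also separates from 2-hydroxypyridin-4-yl (a 4.7-fold lower number from compound 1 to compound 3 (0.67 log units; beyond the scatter)), so among these three compounds the position is not indifferent to the choice of ring, and compound 3 has the lowest number. No measurement on hand gives a reason for this step.

The step from compound 2 to compound 3 changes two things at once, the loss of the methoxy group and a ring with 2 hetero atoms in place of 1, and the compounds shown cannot separate these; an unsubstituted pyridin-2-yl ring or a methoxy-bearing pyrazine ring would do so. Also open, as far as these compounds go, is whether the amide position requires an aromatic ring at all, as a saturated ring such as piperidine or morpholine on the carbonyl carbon would test.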